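Ethynyl for Methyl at the Anomeric Carbon of Compound 2

The source may report more compounds than this note shows. Statements on the series, on what has been measured and on what is new or still open speak of the compounds shown alone.

Compound 1 `Nc1ncnn2c([C@@H]3O[C@H](CO)[C@@H](O)[C@H]3O)ccc12` and compound 2 `C[C@@]1(c2ccc3c(N)ncnn23)O[C@H](CO)[C@@H](O)[C@H]1O` share one core. In an ADME assay on MT4 cells (Homo sapiens) for cytotoxicity, with a stated time of 5 days (a higher number here means that more compound is tolerated, a lower number that less compound is tolerated), compound 1 reaches only a limit, < 10 nM. In this assay, for the measured compounds named here, compound 2 gives 4500 nM, the sole number among the two results. The other result, that of compound 1, is a limit (the limit of < 10 nM in this assay, at which 1 of the 2 values shown sits). Compound 3 `C#C[C@@]1(c2ccc3c(N)ncnn23)O[C@H](CO)[C@@H](O)[C@H]1O` carries ethynyl in place of methyl on a saturated ring carbon. Going by the values given here, with no measured step between two compounds to lean on, a modest shift toward less tolerance is expected for compound 3, a 1.8-fold lower number from compound 2 to compound 3 (0.26 log units; within the scatter), within or just beyond the usual scatter. Compound 3 is therefore estimated at 2500 nM, between 500 nM and 12000 nM.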

Compound 3, half-maximal cytotoxic concentration: 120000 nM
Estimate against measurement, compound 3: 48-fold (1.68 log units) below, outside the stated range (above it).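

Ethynyl in place of methyl on the saturated ring carbon next to the ring oxygen brings a 27-fold higher number from compound 2 to compound 3 (1.43 log units; beyond the scatter) in this assay, so more compound is tolerated. For the compounds shown here, this is the first readable step at this position, and it shows that tolerance is highly sensitive to a small change in the group there. Nothing shown accounts for the size of this step.

The compounds shown leave open whether a nitrile or a longer chain such as propyl on this carbon would shift tolerance in the same direction. They also leave open how far the step depends on the triple bond itself.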